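The source may hold more compounds than are shown below. What is called first, only, known or untested is meant among the compounds shown, and "the series" means these compounds.

Measured so far:

- compound 1, `CC(C)C[C@H](NC(=S)Nc1ccccc1)c1nc2ccccc2[nH]1`: 28900 nM
- compound 2, `CC(C)C[C@@H](NC(=S)Nc1cc(C(F)(F)F)cc(C(F)(F)F)c1)c1nc2ccccc2[nH]1`: 16500 nM
- compound 3, `C[C@@H](NC(=S)NCc1ccccc1)c1nc2ccccc2[nH]1`: 28700 nM

In a functional assay on DU-145 cells (Homo sapiens) for cytotoxicity, read by MTT assay (on this read-out higher numbers stand for weaker inhibition and lower numbers for stronger inhibition), compound 2 gives the lowest of the three numbers, yet the gaps to compound 1 and to compound 3 both fall inside the scatter, so the three stand at about one level. Within the data shown here, no pair among them differs in a single place, so no step is available to read across.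

Compound 4, `C[C@@H](NC(=S)Nc1cc(C(F)(F)F)cc(C(F)(F)F)c1)c1nc2ccccc2[nH]1`, remains to be measured in this assay. Against compound 2 it shows (hydrogen in place of isopropyl on a saturated chain carbon, two bonds along the chain from an amide-type nitrogen and an aromatic carbon). Compounds 1 and 3, which carry the isobutyl and the methyl chain but also differ elsewhere, give values that sit together, which suggests the chain length alone is not decisive here. The step of a 1.3-fold higher number from compound 2 to compound 4 (0.12 log units; within the scatter) is therefore expected to be small, at most a modest loss, and not clearly beyond the scatter. For compound 4 the estimate is 22000 nM, with a range from 9000 nM to 55000 nM.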

Compound 4, half-maximal inhibitory concentration: 17600 nM
Beside the measured number, compound 4's estimate is 1.3-fold (0.10 log units) above it; the range from low to high includes it.
By their numbers in this assay, from the lowest: compounds 2, 4, 3 and 1 (each within the scatter of the next).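

In this assay, hydrogen in place of isopropyl on a saturated chain carbon, two bonds along the chain from an amide-type nitrogen and an aromatic carbon, gives a 1.1-fold higher number from compound 2 to compound 4 (0.03 log units; within the scatter) and leaves the two numbers at one level. Among these compounds, this is the only single-place comparison so far, and it shows directly what compounds 1 and 3 could not: with the rest of the structure held, the isobutyl and methyl forms cannot be told apart on this read-out. Nothing measured here offers an explanation for this flat step.

On these data alone, it remains open whether a longer chain such as hexyl, or a chain ending in an amine or a carboxylic acid, would move the number beyond the scatter at this carbon. As far as these compounds go, it also remains open whether the same change would read the same way with an unsubstituted phenyl in place of the bis(trifluoromethyl)phenyl group.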